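Three Measured Analogues and a Fourth Awaiting Measurement

The source may report more compounds than this note shows. Statements on the series, on what has been measured and on what is new or still open speak of the compounds shown alone.

Compound 1, `Nc1scc(CN2CCN(c3cccc(C(F)(F)F)c3)CC2)c1C(=O)c1ccc(Cl)cc1`: 0%
Compound 2, `Nc1scc(CN2CCN(C3CCCC3)CC2)c1C(=O)c1ccc(Cl)cc1`: 3%
Compound 3, `Nc1scc(CN2CCN(c3ccccc3F)CC2)c1C(=O)c1ccc(Cl)cc1`: 0%

In an assay on CHO cells for displacement of a labelled ligand from adenosine receptor A3 (Homo sapiens), read by scintillation counting, with a stated time of 120 min, tested at 10 uM (a lower number here means less inhibition, a higher number more inhibition at the concentration tested (going by the name of the read-out)), compound 1 gives 0%. It stands level with compound 3, and together these two are the lowest of the three numbers; the furthest from compound 1 is compound 2, whose step is a number 3 percentage points higher from compound 1 to compound 2 (within the scatter). The third measured pair shows a number 3 percentage points lower from compound 2 to compound 3 (within the scatter). None of the three compounds reaches a reading that rises above the scatter.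

Compound 4, `Nc1scc(CN2CCN(CCCc3ccc(Cl)cc3)CC2)c1C(=O)c1ccc(Cl)cc1`, differs from compound 1 in one place: 3-(4-chlorophenyl)propyl in place of 3-(trifluoromethyl)phenyl on an amine nitrogen in a ring. The measured steps that bear on this change are those that also replace the same group on the same ring nitrogen, namely a number 3 percentage points higher from compound 1 to compound 2 (within the scatter) and no change at the digits printed from compound 1 to compound 3 (within the scatter). Both lie within the scatter, and neither an aliphatic ring nor a second aromatic ring moved the reading. The new group is a chain ending in an aromatic ring, a kind of change not yet measured in this set, but nothing measured points to a step beyond the scatter. Compound 4 is therefore expected to show a number 2 percentage points higher from compound 1 to compound 4 (within the scatter). Compound 4 is estimated at 2%, within a range from -8% to 14%.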

Compound 4, a percentage reported as inhibition, at one concentration (the size of the read-out at that concentration, not a potency): 0%
Compound 4: middle estimate off by 2 percentage points, on the high side; the measured number falls inside the stated range.
By their numbers in this assay, from the lowest: compounds 1, 3, 4 and 2 (each within the scatter of the next).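

In this assay, compound 4 extends this ring nitrogen to a chain ending in an aromatic ring, and its reading stays within the scatter of all three earlier compounds (no change at the digits printed from compound 1 to compound 4 (within the scatter); no change at the digits printed from compound 3 to compound 4 (within the scatter); a number 3 percentage points lower from compound 2 to compound 4 (within the scatter)). An aromatic ring on the nitrogen, a cyclopentyl ring and now 3-(4-chlorophenyl)propyl thus all give readings that do not rise above the scatter at the concentration tested, so the longer reach of this group brings nothing new to the reading. Nothing at hand explains why these readings stay so close.

As far as these compounds go, it remains open whether a shorter chain, or an amine or a carboxylic acid in place of the 4-chlorophenyl end, would give a reading beyond the scatter. The compounds shown also leave open whether a change elsewhere on the shared core would do so.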